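A few compounds are considered here, and "the series" means these few. Any claim that something is new, unique, unknown or untested is made for them only; others in the source may bear on it.

Measured so far in a functional assay on the whole organism (6C3HED cells, Mus musculus) for inhibition, at a dose of 150 mg/kg by the oral route; a lower number here means less inhibition, a higher number more inhibition at the dose given (going by the name of the read-out): compound 1 `O=C(Nc1ccc(Cl)cc1)NS(=O)(=O)c1cccs1` gives 16%; compound 2 `O=C(Nc1ccc(Cl)cc1)NS(=O)(=O)c1ccc(Cl)s1` gives 58%; compound 3 `CCc1ccc(S(=O)(=O)NC(=O)Nc2ccc(Cl)cc2)s1` gives 57%.

Compound 3 stands second highest of the three; its nearest neighbour is compound 2, lying within the scatter, its furthest compound 1. Compound 4 `CCc1ccsc1S(=O)(=O)NC(=O)Nc1ccc(Cl)cc1` differs from compound 3 by 3-ethylthiophen-2-yl in place of 5-ethylthiophen-2-yl on a sulfonyl sulfur. Among the compounds with values here, no measured step moves a group around the thiophene ring; the bearing steps are a number 41 percentage points higher from compound 1 to compound 3 (beyond the scatter) and a number 1 percentage points lower from compound 2 to compound 3 (within the scatter), which show that a group on the thiophene raises the read-out, while its nature matters little. Going by these compounds, whether the new position retains this is unknown, so a step of a number 12 percentage points lower from compound 3 to compound 4 (beyond the scatter) in this assay is expected, with wide uncertainty. Compound 4 is estimated at 45%, range 15% to 72%.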

Compound 4, a percentage reported as inhibition, in the whole organism at one dose (the size of the read-out at that dose, not a potency): 21%
The estimate for compound 4 lay 24 percentage points above the measured number; the range from low to high includes it.
By their numbers in this assay, from the lowest: compounds 1 and 4 (each within the scatter of the next); then compounds 3 and 2 (each within the scatter of the next).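

In this assay the change to 3-ethylthiophen-2-yl from 5-ethylthiophen-2-yl gives a number 36 percentage points lower from compound 3 to compound 4 (beyond the scatter) and so the place of the ethyl on the thiophene matters, not only its presence. The change from 5-chlorothiophen-2-yl gives a number 37 percentage points lower from compound 2 to compound 4 (beyond the scatter) and ethyl in place of hydrogen at this new position gives a number 5 percentage points higher from compound 1 to compound 4 (within the scatter) so the gain seen with 5-ethylthiophen-2-yl does not appear here. Nothing available accounts for this loss.

Open, going by these compounds, is whether 3-chlorothiophen-2-yl or 3-methylthiophen-2-yl would match 3-ethylthiophen-2-yl. Also open, on these data alone, is whether a methoxy group in place of the ethyl of compound 3 would keep the read-out.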